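Triazole in Place of Thiazole on a Weak Amide Series

The source may hold more compounds than are shown below. What is called first, only, known or untested is meant among the compounds shown, and "the series" means these compounds.

Compound 3 `Cc1ccc(CNC(=O)c2cccc(C(C)Oc3cccnc3Nc3nccs3)c2)cc1` gives 15300 nM in a functional assay on NCI-H3122 cells (Homo sapiens) for antiproliferative activity, read by MTT assay, with a stated time of 48 h (on this read-out lower numbers stand for stronger inhibition and higher numbers for weaker inhibition), the lowest of the two numbers recorded there. Compound 1 `COc1cccc(CNC(=O)c2cccc(C(C)Oc3cccnc3Nc3cnn(C)c3)c2)c1` gives 49400 nM. Compound 2 `CC(Oc1cccnc1Nc1cnn(C)c1)c1cccc(C(=O)NCc2ccccc2S(=O)(=O)C(C)C)c1` gives only > 100000 nM, a limit of the assay rather than a number. Going by the values given here, the single measured step, an at least 2.0-fold higher number from compound 1 to compound 2 (0.30 log units; that floor lies within the scatter), alters the ring bound through a saturated chain carbon to the amide-type nitrogen and leaves the nitrogen on the aromatic ring untouched. Compound 4 `Cc1ccc(CNC(=O)c2cccc(C(C)Oc3cccnc3Nn3cnnc3)c2)cc1` differs from compound 3 exactly there: 4H-1,2,4-triazol-4-yl in place of 1,3-thiazol-2-yl on a nitrogen on an aromatic ring. Among the compounds with values here, no measured step bears on this change, so only a loose expectation is possible. The step expected is a 2.3-fold higher number from compound 3 to compound 4 (0.36 log units; beyond the scatter). Compound 4 is estimated at 35000 nM, within a range from 8000 nM to 150000 nM.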

Compound 4, half-maximal inhibitory concentration: 23700 nM
For compound 4 the middle estimate is 1.5-fold (0.17 log units) above the measured one; the range from low to high includes it.
By their numbers in this assay, from the lowest: compounds 3 and 4 (each within the scatter of the next); then compound 1. At a limit, above all of these: compound 2.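

Placing 4H-1,2,4-triazol-4-yl in place of 1,3-thiazol-2-yl on the nitrogen gives, in this assay, a 1.5-fold higher number from compound 3 to compound 4 (0.19 log units; within the scatter). At this place, then, a ring with 3 hetero atoms and a ring with 2 cannot be told apart in this read-out. Nothing measured here accounts for this result. As far as these compounds go, what a phenyl ring or a carboxylic acid would do at this place remains open. So does whether the same exchange would give a similar step with the 3-methoxyphenyl group of compound 1.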